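Imidazolylmethyl replacement on the ring-amine carbon of compound 1

A few compounds are considered here, and "the series" means these few. Any claim that something is new, unique, unknown or untested is made for them only; others in the source may bear on it.

Measured so far in an assay on isolated protein for activation of cGMP-dependent protein kinase 1 (Homo sapiens), read by ADP-Glo, with stated times of 30 min and 2 h, in the presence of a further agent that is not named here; on this read-out lower numbers stand for an effect already at smaller amounts and higher numbers for an effect only at larger amounts of compound:
Compound 1 `O=C(O)C12CC(CN3CCC[C@H](O[C@H](CO)c4cc(Cl)cc(Cl)c4)[C@@H]3c3ccccc3)(C1)C2` gives 12000 nM in this assay.
Compound 2 `Cc1cc(C(=O)O)ccc1CN1CCC[C@H](O[C@H](CO)c2cc(F)cc(F)c2)[C@@H]1c1ccccc1` gives 1500 nM in this assay.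

Compound 1 stands at the higher of the two numbers; compound 2 sits well lower, beyond the usual scatter. For the measured compounds named here, no pair differing in one place has been measured, so no single-change step is known.

Compound 3 `OC[C@@H](O[C@H]1CCCN(Cc2ncc[nH]2)[C@H]1c1ccccc1)c1cc(Cl)cc(Cl)c1` arises from compound 1 by a group of 5 heavy atoms (3 carbon, 2 nitrogen; one five-membered aromatic ring with 2 hetero atoms) in place of a group of 8 heavy atoms (6 carbon, 2 oxygen; 2 four-membered non-aromatic rings of carbon only), on a saturated chain carbon bound to an amine nitrogen in a ring. This removes the larger bicyclic substituent and its acid function and puts in a small five-membered aromatic ring on the chain carbon bound to the ring amine. Going by the values given here, the only comparison at hand, compound 1 against compound 2, shows that a change at this same region of the molecule can move the number substantially, but that pair also differs in the halogens on the aryl ring, so it gives no clean guide.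

For compound 3 the expectation is a step from compound 1 in this assay of a 1.7-fold higher number from compound 1 to compound 3 (0.22 log units; within the scatter), likely a modest rise or no clear change beyond the scatter. The estimate for compound 3 is 20000 nM, with a range of 4000 nM to 80000 nM.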

Compound 3, half-maximal effective concentration: 47000 nM
For compound 3 the middle estimate is 2.4-fold (0.37 log units) below the measured one, within the range that was stated.
By their numbers in this assay, from the lowest: compound 2; then compound 1; then compound 3.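

In this assay, placing 1H-imidazol-2-yl on the saturated chain carbon bound to an amine nitrogen in a ring, in place of the group of 8 heavy atoms (6 carbon, 2 oxygen), gives a 3.9-fold higher number from compound 1 to compound 3 (0.59 log units; beyond the scatter). For the compounds shown here, this is the first single-place step, and it shows that this place affects the read-out while the rest of the molecule stays fixed. The step is modest but beyond the usual scatter, and no data on hand separate the contributions of the ring type, the size of the group or the loss of the carboxylic acid.

The compounds shown leave open whether the step follows from the five-membered aromatic ring itself or from the removal of the larger group with its two four-membered rings. A tetrazole or a primary amide on the same chain carbon, or a 1H-imidazol-2-yl group held further out on a longer chain, would help to separate these readings.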